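The source may report more compounds than this note shows. Statements on the series, on what has been measured and on what is new or still open speak of the compounds shown alone.

For the measured compounds named here, in a functional assay on WM 266-4 cells (Homo sapiens) for antiproliferative activity, read by MTT assay, with a stated time of 24 h (on this read-out lower numbers stand for stronger inhibition of growth and higher numbers for weaker inhibition of growth), compound 2 `Clc1ccc(C2CC(c3ccc4c(c3)OCCO4)=NN2c2ccccc2)cc1` gives 38600 nM, the higher of the two numbers so far. Going by the values given here, the only other measured compound, compound 1 `Ic1ccc(C2CC(c3ccc4c(c3)OCCO4)=NN2c2ccccc2)cc1`, gives 3470 nM. Compound 3 `CSc1ccc(C2CC(c3ccc4c(c3)OCCO4)=NN2c2ccccc2)cc1` keeps the shared core and carries methylsulfanyl in place of chloro on an aromatic carbon, para to a large group: methylsulfanyl in place of chloro on an aromatic carbon.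

Among the compounds with values here, the one measured step that bears on this change is an 11-fold higher number from compound 1 to compound 2 (1.05 log units; beyond the scatter), chloro in place of iodo on an aromatic carbon. It shows that exchanging the substituent at this place can move the number well beyond the scatter. Within the data shown here, no measured compound carries methylsulfanyl, so this single step sets only the likely scale, not the outcome. Compound 2 also sits at the high end of the two numbers, so a move to a lower number is expected, probably smaller than the measured step, with a result within the scatter still possible.

The expected change is a 3.2-fold lower number from compound 2 to compound 3 (0.51 log units; beyond the scatter). The estimate for compound 3 is 12000 nM, with an expected range of 3000 nM to 40000 nM.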

Compound 3, concentration for 50% growth inhibition: 6870 nM
For compound 3 the middle estimate is 1.7-fold (0.24 log units) above the measured one; the measured number falls inside the stated range.
By their numbers in this assay, from the lowest: compounds 1 and 3 (each within the scatter of the next); then compound 2.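

In this assay, for the compounds shown here, the position now also carries a substituent other than a halogen: methylsulfanyl in place of chloro gives a 5.6-fold lower number from compound 2 to compound 3 (0.75 log units; beyond the scatter), so the earlier step from iodo is no longer the only exchange that moves the number beyond the scatter from compound 2. Methylsulfanyl in place of iodo gives a 2.0-fold higher number from compound 1 to compound 3 (0.30 log units; within the scatter), which lies within the scatter, so this assay does not separate these two substituents, and compound 2 alone stands apart, with its steps to both other compounds beyond the scatter. Nothing measured in this series bears on the reason for these steps.

With three compounds differing at this one aromatic carbon, no trend can be drawn beyond these three substituents. Open questions are what an amine, a carboxylic acid or a longer chain such as ethylsulfanyl would give at this carbon, and whether the same steps would hold on a core other than the shared one.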